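This account rests on a few compounds, and the source may have more. Where it says the series, first, only, none or still open, it means among the compounds named here.

Measured in a functional assay (Homo sapiens) for antiproliferative activity, read by resazurin assay, with a stated time of 48 h, tested at 10 uM; a higher number here means a stronger effect of the compound at the concentration tested, a lower number a weaker effect: compound 1 `COc1cc(OC)c2c(=O)cc(-c3ccc(OCCF)cc3)oc2c1`, "not active" (no number reported); compound 2 `COc1cc(OC)c2c(=O)cc(-c3ccc(OCCCN(C)C)cc3)oc2c1`, 59%; compound 3 `COc1cc(OC)c2c(=O)cc(-c3ccc(OC4CCNCC4)cc3)oc2c1`, 21%.

Compound 3 holds the lowest of the two numbers; compound 2 lies higher by a number 38 percentage points lower from compound 2 to compound 3 (beyond the scatter), a step beyond the scatter, and compound 1 is reported without a number.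

Compound 4 `COc1cc(OC)c2c(=O)cc(-c3ccc(OCCN)cc3)oc2c1` differs from compound 3 by 2-aminoethyl in place of piperidin-4-yl on an oxygen on an aromatic ring. For the measured compounds named here, only one measured step touches the group on this oxygen, a number 38 percentage points lower from compound 2 to compound 3 (beyond the scatter), a large drop; it exchanged 3-(dimethylamino)propyl for piperidin-4-yl. Going by the values given here, no measured step exchanges piperidin-4-yl for 2-aminoethyl, so the direction of this change cannot be read from the series. The step of a number 7 percentage points higher from compound 3 to compound 4 (within the scatter) is therefore expected to stay within the scatter. Compound 4 is estimated at 28%, range 5% to 55%.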

Compound 4, a percentage reported as inhibition, at one concentration (the size of the read-out at that concentration, not a potency): 35%
For compound 4 the middle estimate is 7 percentage points below the measured one, within the range that was stated.
By their numbers in this assay, from the lowest: compound 3; then compound 4; then compound 2.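

In this assay the group on this oxygen also moves the read-out when the ring gives way to an open chain, with a number 14 percentage points higher from compound 3 to compound 4 (beyond the scatter) on going to 2-aminoethyl. That chain still does not match 3-(dimethylamino)propyl, with a number 24 percentage points lower from compound 2 to compound 4 (beyond the scatter), so the three nitrogen-bearing groups separate beyond the scatter. No available evidence accounts for this order.

Still open, going by these compounds, is whether chain length or the substitution on the nitrogen sets the difference between the two open chains. A 3-aminopropyl or 2-(dimethylamino)ethyl group on this oxygen would separate the two.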